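The source may hold more compounds than are shown below. What is called first, only, known or untested is meant among the compounds shown, and "the series" means these compounds.

Measured compounds:
- Compound 1 `CN(C)CCCNc1ccnc2cc(OCc3ccc(F)cc3)ccc12`: 1280 nM
- Compound 2 `CCOc1ccc2c(NCCN(C)C)ccnc2c1`: 4620 nM

In a functional assay on SK-OV-3 cells (Homo sapiens) for cytotoxicity, read by MTT assay, with a stated time of 48 h (on this read-out lower numbers stand for stronger inhibition and higher numbers for weaker inhibition), compound 1 gives 1280 nM. In this assay compound 2 gives 4620 nM, the higher of the two numbers; the gap between the number for compound 2 and the lower one for compound 1 lies beyond the usual scatter, but the two compounds differ in more than one place, so no single step can be read from them.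

Compound 3 `CCOc1ccc2c(NCCCN(C)C)ccnc2c1` keeps the core of compound 2 and differs from it by (dimethylamino)methyl in place of dimethylamino on a saturated chain carbon, two bonds along the chain from a nitrogen on an aromatic ring. Compound 1 also carries the 3-(dimethylamino)propyl chain, yet its ether differs from that of compound 2, so the chain change cannot be isolated from the numbers at hand. With that caution, compound 3 is expected to show a small step, if any, toward a lower number, a 1.5-fold lower number from compound 2 to compound 3 (0.19 log units; within the scatter). The estimate for compound 3 in this assay is 3000 nM, with a range from 1200 nM to 7500 nM.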

Compound 3, half-maximal inhibitory concentration: 6780 nM
Compound 3: middle estimate off by 2.3-fold (0.35 log units), on the low side, and the stated range covers the measured number.
By their numbers in this assay, from the lowest: compound 1; then compounds 2 and 3 (each within the scatter of the next).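

In this assay, 3-(dimethylamino)propyl in place of 2-(dimethylamino)ethyl on the shared core gives a 1.5-fold higher number from compound 2 to compound 3 (0.17 log units; within the scatter), so at this position the extra chain carbon gives a pair of numbers that the scatter cannot separate. Within the data shown here, with that chain now held the same, the ether can be read on its own for the first time: methyl in place of 4-fluorophenyl on a saturated chain carbon bound to an oxygen on an aromatic ring gives a 5.3-fold higher number from compound 1 to compound 3 (0.72 log units; beyond the scatter), a modest step beyond the scatter. Nothing at hand gives a reason for either step.

From the compounds shown here alone, whether a longer chain, or a piperidine in place of the dimethylamino end, would shift the number remains open. So does whether an unsubstituted phenyl in place of 4-fluorophenyl would keep the lower number of compound 1.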